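Swapping a Methylthiophene for a Methyl-Oxadiazole

The compounds below may be only part of what the source reports. "The series", "measured", "known", "first", "only" and "open" are said of these compounds alone.

compound 1, `c1csc(-c2ccccc2NCC2=NCCN2)c1`: 18.2 nM in a functional assay for activation of Alpha-1D adrenergic receptor (Homo sapiens); on this read-out higher numbers stand for an effect only at larger amounts of compound and lower numbers for an effect already at smaller amounts
compound 2, `Cc1cc(-c2ccccc2NCC2=NCCN2)on1`: < 100000 nM in this assay, a limit
compound 3, `Cc1ccsc1-c1ccccc1NCC1=NCCN1`: 49 nM in this assay

Compound 3 holds the higher of the two readable numbers in this assay; its nearest neighbour is compound 1, and the step of a 2.7-fold higher number from compound 1 to compound 3 (0.43 log units; beyond the scatter) separates them. The third value belongs to compound 2 and is a limit of the assay, not a number.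

Compound 4, `Cc1nc(-c2ccccc2NCC2=NCCN2)no1`, differs from compound 3 by 5-methyl-1,2,4-oxadiazol-3-yl in place of 3-methylthiophen-2-yl on an aromatic carbon. Among the measured compounds shown here, the only fully readable step among the measured compounds is a 2.7-fold higher number from compound 1 to compound 3 (0.43 log units; beyond the scatter), which concerns a methyl alone and not a ring swap. From the compounds shown here alone, the ring swaps themselves, a step that the limit leaves unreadable from compound 1 to compound 2 and a step that the limit leaves unreadable from compound 2 to compound 3, are left unreadable by the limit, so their size is unknown. The incoming 5-methyl-1,2,4-oxadiazol-3-yl resembles the 3-methyl-1,2-oxazol-5-yl of compound 2 more than the thiophenes of compounds 1 and 3, so a number higher than that of compound 3 is expected, with the size uncertain; compound 4 is estimated at 1500 nM, within 100 nM to 30000 nM, which would mean a step of a 31-fold higher number from compound 3 to compound 4 (1.49 log units; beyond the scatter).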

Compound 4, half-maximal effective concentration: < 5020 nM
Compound 4 ended at the assay's limit (the forecaster's own chance of this, stated with the estimate: 30%); the middle value does not contradict the limit.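

In this assay compound 4 gives < 5020 nM, which is a limit and not a number. None of its steps to compound 1, compound 2 or compound 3 can be read. The compounds shown leave open how far the rings of compound 2 and compound 4 stand from the thiophenes of compound 1 and compound 3 in this read-out.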